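A few compounds are considered here, and "the series" means these few. Any claim that something is new, unique, unknown or untested is made for them only; others in the source may bear on it.

Three compounds share one core and differ only in the aryl group on the triple-bonded carbon. Compound 1 `COC(=O)c1sc2cc(C#Cc3cccc(N)c3)cnc2c1N` gives 10800 nM in a functional assay on MCF7 cells (Homo sapiens) for inhibition, read by sulforhodamine B assay, with a stated time of 48 h (a higher number here means a weaker inhibitor of growth, a lower number a stronger inhibitor of growth), and compound 2 `COC(=O)c1sc2cc(C#Cc3ccc(N)cc3)cnc2c1N` gives 2600 nM in this assay, the step of a 4.2-fold lower number from compound 1 to compound 2 (0.62 log units; beyond the scatter) being modest. Compound 3 `COC(=O)c1sc2cc(C#Cc3ccccc3F)cnc2c1N` reaches only > 150000 nM in this assay, which is a limit of the assay and not a number, as the limit of > 150000 nM in this assay, at which 1 of the 3 values shown sits, records. Compound 3 therefore stands at the weak end of the three. The change to compound 4 `COC(=O)c1sc2cc(C#Cc3ccccc3OC)cnc2c1N` is methoxy in place of fluoro on an aromatic carbon. For the measured compounds named here, the steps that bear on it are an at least 13-fold higher number from compound 1 to compound 3 (1.14 log units; beyond the scatter) and an at least 57-fold higher number from compound 2 to compound 3 (1.76 log units; beyond the scatter), both large, but both swap an aminophenyl for the fluorophenyl; no measured step swaps fluoro for methoxy, so the two steps say only that compound 3 sits far from the two amines. Compound 4 is expected to stay weak, with an estimated 100000 nM in this assay and a range from 20000 nM to 400000 nM. The expected step is an at least 1.5-fold lower number from compound 3 to compound 4 (0.17 log units; that floor lies within the scatter), and a limit value is again plausible.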

Compound 4, concentration for 50% growth inhibition: > 47300 nM
Compound 4 ended at the assay's limit; the forecaster's own chance of this, stated with the estimate: 50%; the middle value lies beyond the limit too.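

Compound 4 gives no number in this assay, only a limit of the assay: the limit of > 47300 nM in this assay, at which 1 of the 4 values shown sits. Even so, the 2-methoxyphenyl group lies clearly on the weak side of both amines, with an at least 18-fold higher number from compound 2 to compound 4 (1.25 log units; beyond the scatter) and an at least 4.3-fold higher number from compound 1 to compound 4 (0.64 log units; beyond the scatter), so a second group on the aromatic carbon ortho to a large group now falls short of the aminophenyl compounds, as the fluoro group of compound 3 did. The step between compound 3 and compound 4 cannot be read, as both sit at limits, so methoxy and fluoro cannot be ranked against each other.

The compounds shown leave open whether any group on this carbon gives a readable value. A 2-aminophenyl group would test whether the amine keeps its effect at this place, and an unsubstituted phenyl would show how the ring behaves with no group there at all.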